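The compounds below may be only part of what the source reports. "The series", "measured", "known", "first", "only" and "open" are said of these compounds alone.

Three compounds that share one core were tested in a functional assay on Hep 3B2 cells (Homo sapiens) for antiproliferative activity, read by MTT assay, with a stated time of 24 h, tested at 33.33 ug/mL; a higher number here means a stronger effect of the compound at the concentration tested, a lower number a weaker effect. Compound 1 `Cc1ccc2nc(C(=O)Nc3c(F)cc(-c4cccc(F)c4)cc3F)c(C)c(C(=O)O)c2c1` gives 41.3%. Compound 2 `CCc1ccc2nc(C(=O)Nc3c(F)cc(-c4cccc(F)c4)cc3F)c(C)c(C(=O)O)c2c1` gives 36.3%, and compound 3 `CCOc1ccc2nc(C(=O)Nc3c(F)cc(-c4cccc(F)c4)cc3F)c(C)c(C(=O)O)c2c1` gives 38.7%. The three numbers lie close together: a number 5 percentage points higher from compound 2 to compound 1 (within the scatter), a number 2.6 percentage points lower from compound 1 to compound 3 (within the scatter), and a number 2.4 percentage points higher from compound 2 to compound 3 (within the scatter), so none of them can be told apart from the others with confidence.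

Compound 4 `COc1ccc2nc(C(=O)Nc3c(F)cc(-c4cccc(F)c4)cc3F)c(C)c(C(=O)O)c2c1` has not yet been measured. It differs from compound 3 by hydrogen in place of methyl on a saturated chain carbon bound to an oxygen on an aromatic ring. Compound 1 differs from compound 2 by hydrogen in place of methyl on a saturated chain carbon bound to an aromatic carbon, a change of the same kind, though not the same: in compound 2 the chain carbon is bound to an aromatic carbon, whereas in compound 3 it is bound to an oxygen on an aromatic ring. The cores of compound 2 and compound 3 themselves differ by ethoxy in place of ethyl on an aromatic carbon.

Among the compounds with values here, the expected step is a number 1.3 percentage points higher from compound 3 to compound 4 (within the scatter), small because the one earlier step of this kind was a number 5 percentage points higher from compound 2 to compound 1 (within the scatter). Compound 4 is accordingly estimated to give 40% in this assay, with a likely range from 30% to 50%.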

Compound 4, a percentage reported as inhibition, at one concentration (the size of the read-out at that concentration, not a potency): 7.24%
Estimate against measurement, compound 4: 32.8 percentage points above; measured number below the stated range.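

In this assay, shortening ethoxy to methoxy gives a number 31.5 percentage points lower from compound 3 to compound 4 (beyond the scatter), and compound 4 also stands apart from the two compounds with an alkyl group at that place, with a number 29.1 percentage points lower from compound 2 to compound 4 (beyond the scatter) and a number 34.1 percentage points lower from compound 1 to compound 4 (beyond the scatter). The change of hydrogen in place of methyl at the end of a chain therefore does not carry over from one core to the other in this assay: the same change on two cores in this assay, a number 5 percentage points higher (within the scatter) from compound 2 to compound 1 and a number 31.5 percentage points lower (beyond the scatter) from compound 3 to compound 4, 36.5 percentage points apart, beyond the scatter of two such steps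

This finding rests on a single pair of steps at one tested concentration, so it does not show why the two steps differ or how the same change would behave on any further core.

The compounds shown leave open whether the low number belongs to the methoxy group alone. A hydroxyl group, an amine or a longer chain such as propoxy on that aromatic carbon could help to settle this.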